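One Swap, Measured Once, Expected Again

A few compounds are considered here, and "the series" means these few. Any claim that something is new, unique, unknown or untested is made for them only; others in the source may bear on it.

Of the compounds shown here, three have been tested in a functional assay on RPMI-8226 cells (Homo sapiens) for cytotoxicity, read by sulforhodamine B assay, with a stated time of 48 h; on this read-out lower numbers stand for stronger inhibition of growth and higher numbers for weaker inhibition of growth. Compound 3 `ClCc1ccc(Cn2cnc3c(Cl)nc(Cl)nc32)cc1` gives 1740 nM. Compound 1 `Nc1nc(Cl)c2ncn(Cc3ccc(CCl)cc3)c2n1` differs from it by amino in place of chloro on an aromatic carbon. In this assay compound 1 gives 3800 nM. That change made a step of a 2.2-fold higher number from compound 3 to compound 1 (0.34 log units; beyond the scatter). Compound 2 `ClCc1cccc(Cn2cnc3c(Cl)nc(Cl)nc32)c1` has the same atoms as compound 3 joined differently; the difference between the two cores is not broken down here. In this assay compound 2 gives 3310 nM, a value within the usual scatter of both other measured values. Compound 4 `Nc1nc(Cl)c2ncn(Cc3cccc(CCl)c3)c2n1` has not yet been measured; it differs from compound 2 by amino in place of chloro on an aromatic carbon, the same change that turned compound 3 into compound 1. For compound 4 a step of about that size is expected, a 2.1-fold higher number from compound 2 to compound 4 (0.33 log units; beyond the scatter), because the earlier step of a 2.2-fold higher number from compound 3 to compound 1 (0.34 log units; beyond the scatter) lay beyond the scatter. Compound 4 is therefore estimated at 7000 nM, with a likely range from 3500 nM to 14000 nM.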

Compound 4, concentration for 50% growth inhibition: 2390 nM
Compound 4: middle estimate off by 2.9-fold (0.47 log units), on the high side; the whole stated range lies above it.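

In this assay, amino in place of chloro on an aromatic carbon gives a 1.4-fold lower number from compound 2 to compound 4 (0.14 log units; within the scatter), so on this core the swap produces no change that can be told from the scatter. The swap therefore did not carry over from one core to the other with the same effect: the same change on two cores in this assay, a 2.2-fold higher number (0.34 log units; beyond the scatter) from compound 3 to compound 1 and a 1.4-fold lower number (0.14 log units; within the scatter) from compound 2 to compound 4, 3.0-fold (0.48 log units) apart, beyond the scatter of two such steps

This shows that, in these two pairs, the result of the swap differed with the core, but two pairs cannot show which feature of the cores matters or how the swap would behave on a further core.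

The compounds shown leave open whether a methoxy or dimethylamino group on the same aromatic carbon would also differ between the two cores. They also leave open whether either group would give a step beyond the scatter on both.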